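Chloro-to-fluoro step from compound 3 to compound 4

This account rests on a few compounds, and the source may have more. Where it says the series, first, only, none or still open, it means among the compounds named here.

Measured compounds, values in a functional assay on HL-60 cells (Homo sapiens) for inhibition, read by CCK-8 assay, with a stated time of 48 h, tested at 20 uM; on this read-out higher numbers stand for more inhibition of growth at the one concentration tested and lower numbers for less inhibition of growth:
Compound 1 `N#C/C(=C\c1ccccc1OS(=O)(=O)c1ccc(Cl)cc1)C(=O)Nc1nnc(Cc2ccc(F)cc2)s1` gives 20%.
Compound 2 `N#C/C(=C\c1ccccc1OS(=O)(=O)c1ccc(F)cc1)C(=O)Nc1nnc(Cc2ccc(F)cc2)s1` gives 13%.
Compound 3 `Cc1ccc(Cc2nnc(NC(=O)/C(C#N)=C/c3ccccc3OS(=O)(=O)c3ccc(Cl)cc3)s2)cc1` gives 38%.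

Compound 3 stands highest of the three, beyond the scatter against both compound 1 and compound 2. The cores of compound 1 and compound 3 differ by methyl in place of fluoro on an aromatic carbon, and this gave a number 18 percentage points higher from compound 1 to compound 3 (beyond the scatter).

Compound 4 `Cc1ccc(Cc2nnc(NC(=O)/C(C#N)=C/c3ccccc3OS(=O)(=O)c3ccc(F)cc3)s2)cc1` is not yet measured. It differs from compound 3 by fluoro in place of chloro on an aromatic carbon. The same change separates compound 1 from compound 2, (fluoro in place of chloro on an aromatic carbon), and the two place descriptions read the same word for word, so the step is counted as the same change; it gave a number 7 percentage points lower from compound 1 to compound 2 (within the scatter).

For compound 4 the expected step in this assay is a number 7 percentage points lower from compound 3 to compound 4 (within the scatter), because a number 7 percentage points lower from compound 1 to compound 2 (within the scatter) was the only observed effect of this change and a step of about that size is expected again on the core of compound 3. Compound 4 is estimated at 31%, with a range from 18% to 44%.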

Compound 4, percent growth inhibition at one concentration: 11%
Compound 4: middle estimate off by 20 percentage points, on the high side; the whole stated range lies above it.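

Fluoro in place of chloro gave a number 27 percentage points lower from compound 3 to compound 4 (beyond the scatter) in this assay, so the size of this step did not carry over from one core to the other: the same change on two cores in this assay, a number 7 percentage points lower (within the scatter) from compound 1 to compound 2 and a number 27 percentage points lower (beyond the scatter) from compound 3 to compound 4, 20 percentage points apart, beyond the scatter of two such steps

Methyl in place of fluoro gave a number 2 percentage points lower from compound 2 to compound 4 (within the scatter) in this assay, so this change did not carry over either, and its step depends on which halogen sits on the other aryl ring: the same change on two cores in this assay, a number 18 percentage points higher (beyond the scatter) from compound 1 to compound 3 and a number 2 percentage points lower (within the scatter) from compound 2 to compound 4, 20 percentage points apart, beyond the scatter of two such steps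

Of these four compounds, only compound 3 combines chloro with methyl, and the two changes do not add independently on this read-out, but a single tested concentration on one cell line does not show why, or whether the same holds at other concentrations.

On these data alone, it stays open whether the high number of compound 3 is specific to chloro, or whether a bromo or a methoxy in its place would behave alike. The same question stands for the methyl, where an ethyl or an amine would show whether the effect of that group extends beyond these compounds.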